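A few compounds are considered here, and "the series" means these few. Any claim that something is new, unique, unknown or untested is made for them only; others in the source may bear on it.

Compound 1 `NC(=O)c1cn2c(n1)-c1cc(C#CC3CCCC3)ccc1C1CC2C1` and compound 2 `CNC(=O)c1c(C(N)=O)nc2n1C1CC(C1)c1ccc(C#CC(C)(C)c3ncc(C)o3)cc1-2` share a core, and compound 3 `Cc1cnc(C(C)(C)C#Cc2ccc3c(c2)-c2nc(C(N)=O)c(C4CC4)n2C2CC3C2)o1` belongs to the same series. In an assay on isolated protein for inhibition of mitogen-activated protein kinase kinase kinase 14 (Homo sapiens), read by fluorescence (on this read-out lower numbers stand for stronger inhibition and higher numbers for weaker inhibition), compound 1 gives only a limit, > 1250 nM. Compound 2 likewise gives only a limit in this assay, > 1250 nM, so compound 2 stands at the same limit as the other value shown (the limit of > 1250 nM in this assay, at which 2 of the 2 values shown sit) and cannot be placed any further on the numbers. Going by the values given here, the change cyclopropyl in place of methylcarbamoyl on an aromatic carbon has no measured counterpart. The estimated step that the limit leaves unreadable from compound 2 to compound 3 is expected to be small, not beyond the scatter. Compound 3 is expected to give about 2000 nM, between 300 nM and 10000 nM.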

Compound 3, inhibition constant in the mitogen-activated protein kinase kinase kinase 14 assay: > 1250 nM
Compound 3: a limit, no number; the forecaster's own chance of this, stated with the estimate: 65%; the middle value lies beyond the limit too.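

In the mitogen-activated protein kinase kinase kinase 14 assay compound 2 gives only a limit (> 1250 nM). In the mitogen-activated protein kinase kinase kinase 14 assay compound 3 also gives only a limit (> 1250 nM). No step can be read between them. As far as these compounds go, how strongly compound 1, compound 2 and compound 3 inhibit remains open, as does the effect of cyclopropyl in place of methylcarbamoyl on that inhibition. In a physicochemical assay for lipophilicity, at pH 7.4 (a higher number here means a more lipophilic compound, a lower number a more polar compound), compound 2 gives 3.7 and compound 3 gives 4.4 with cyclopropyl in place of methylcarbamoyl.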